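The source may hold more compounds than are shown below. What is called first, only, known or untested is meant among the compounds shown, and "the series" means these compounds.

Compound 1, `Nc1ccc2cccc(OCC3CCCO3)c2n1`: in an assay on cells with melanin-concentrating hormone receptor 1 (Homo sapiens) as the target, read by radioligand binding (a higher number here means a weaker inhibitor, a lower number a stronger inhibitor), compound 1 gives > 2000 nM, which is a limit of the assay and not a number. Compound 2, `CC(C)C(C)Oc1cccc2ccc(N)nc12`: in this assay compound 2 gives 199 nM. Compound 3, `COCC(C)Oc1cccc2ccc(N)nc12`: in this assay compound 3 gives 606 nM.

Compound 1 therefore stands at the weak end of the three measured compounds, and its position is known only as a limit (the limit of > 2000 nM in this assay, at which 1 of the 3 values shown sits), so the true gap to the others may be larger than shown. Replacing its (oxolan-2-yl)methyl group with a group that has no ring gave a lower number in both measured cases: an at least 10-fold lower number from compound 1 to compound 2 (1.00 log units; beyond the scatter) and an at least 3.3-fold lower number from compound 1 to compound 3 (0.51 log units; beyond the scatter). Between the two ring-free groups, a 3.0-fold higher number from compound 2 to compound 3 (0.48 log units; beyond the scatter).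

Compound 4, `COC(C)(C)CCOc1cccc2ccc(N)nc12`, differs from compound 1 as follows: 2-methoxy-2-methylpropyl in place of oxolan-2-yl on a saturated chain carbon bound to an oxygen on an aromatic ring. Like compound 3, compound 4 carries a methoxy ether in the chain on the oxygen, so the step from compound 1 is expected to resemble that of compound 3 rather than that of compound 2. An improvement beyond the scatter is expected, an at least 4.0-fold lower number from compound 1 to compound 4 (0.60 log units; beyond the scatter). Compound 4 is thus estimated to give 500 nM in this assay, with a likely range from 150 nM to 2000 nM.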

Compound 4, half-maximal inhibitory concentration: 132 nM
The estimate for compound 4 lay 3.8-fold (0.58 log units) above the measured number; the measured number lies below the stated range.
By their numbers in this assay, from the lowest: compounds 4 and 2 (each within the scatter of the next); then compound 3. At a limit, above all of these: compound 1.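

Placing 2-methoxy-2-methylpropyl in the position of oxolan-2-yl gives an at least 15-fold lower number from compound 1 to compound 4 (1.18 log units; beyond the scatter), and the two groups have the same count of hydrogen-bond donors and acceptors, so this step removes the ring without changing that count. For the compounds shown here, until now, the only ring-free group with a methoxy ether was the one in compound 3, which gives 606 nM, whereas in this assay compound 4 gives 132 nM and compound 2 gives 199 nM, two values within the scatter of each other, so a methoxy ether in a ring-free chain on this oxygen is compatible with a number at the level of compound 2. The value for compound 1 is a limit and not a number, so the true size of this step may be larger: the limit of > 2000 nM in this assay, at which 1 of the 4 values shown sits.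

The compounds shown leave open whether an amine or a carboxylic acid on the chain would be tolerated at this position, and how a longer chain would fare. From the compounds shown here alone, it also remains open how much the methoxy of 2-methoxy-2-methylpropyl contributes to the number for compound 4, compared with a chain of carbon alone.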